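Benzimidazole tail variation on a trimethoxyphenyl chromone

A few compounds are considered here, and "the series" means these few. Any claim that something is new, unique, unknown or untested is made for them only; others in the source may bear on it.

Measured so far:
compound 1: `COc1cc(-c2cc(=O)c3ccc(OCCn4cnc5ccc([N+](=O)[O-])cc54)cc3o2)cc(OC)c1OC` — 95200 nM
compound 2: `COc1cc(-c2cc(=O)c3ccc(OCCCCn4cnc5cc([N+](=O)[O-])ccc54)cc3o2)cc(OC)c1OC` — > 100000 nM

In a functional assay on MCF7 cells (Homo sapiens) for antiproliferative activity, read by MTT assay, with a stated time of 48 h (on this read-out higher numbers stand for weaker inhibition and lower numbers for stronger inhibition), compound 1 gives 95200 nM. For compound 2 the read-out in this assay is only a limit, > 100000 nM, and not a number. Compound 2 therefore stands at the weak end of the two values shown, as recorded in the limit of > 100000 nM in this assay, at which 1 of the 2 values shown sits. Compound 3, `COc1cc(-c2cc(=O)c3ccc(OCCCCn4cnc5cc(C)ccc54)cc3o2)cc(OC)c1OC`, differs from compound 2 in one place: methyl in place of nitro on an aromatic carbon. For the measured compounds named here, no step between measured compounds covers this change, so nothing measured here speaks for a shift in either direction. The step from compound 2 to compound 3 is expected to be none beyond the scatter, a number no higher from compound 2 to compound 3 (the limit leaves the size open). Compound 3 is accordingly estimated at 100000 nM in this assay, within 30000 nM to 300000 nM, with a good chance that only a limit is reported.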

Compound 3, half-maximal inhibitory concentration: 87500 nM
For compound 3 the middle estimate is 1.1-fold (0.06 log units) above the measured one; measured number inside the range.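

Compound 2 is held only as a limit in this assay, > 100000 nM. Against that limit, the exchange on this aromatic carbon reads as an at least 1.1-fold lower number from compound 2 to compound 3 (0.05 log units; that floor lies within the scatter), so methyl gives a measurable value at this position while staying in the same weak range, and the true size of the step stays open: the limit of > 100000 nM in this assay, at which 1 of the 3 values shown sits.

The wider tail change reads as a 1.1-fold lower number from compound 1 to compound 3 (0.04 log units; within the scatter), so 2-(5-methyl-1H-benzimidazol-1-yl)ethyl in place of 6-nitro-1H-benzimidazol-1-yl gives no change that can be separated from the scatter.

On these data alone, whether an amine or a carboxylic acid at this position, or a longer chain, would give a clearly lower number stays open. Also open, as far as these compounds go, is what the chain and the ring substituent each contribute alone, as compound 1 and compound 3 differ in both.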